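The source may report more compounds than this note shows. Statements on the series, on what has been measured and on what is new or still open speak of the compounds shown alone.

Two compounds have so far been measured in an ADME assay on Huh-7 cells (Homo sapiens) for cytotoxicity, read by MTT assay, with a stated time of 4 h, at 37 degrees C; a lower number here means that less compound is tolerated, a higher number that more compound is tolerated:

Compound 1 `O=C1Nc2nc(Nc3ccccc3)nc(On3nnc4ccccc43)c2CC1c1ccc(Cl)cc1Cl` gives 5500 nM
Compound 2 `Nc1nc(Nc2ccccc2)nc2[nH]c(=O)c(-c3ccccc3)cc12` gives 13800 nM

Of these two numbers, compound 1 has the lower one, which means that less of it is tolerated by the cells than of compound 2; the gap between them is beyond the usual scatter of this assay, so the two compounds are genuinely told apart.

Compound 3 `O=C1Nc2nc(Nc3ccccc3)nc(On3nnc4ccccc43)c2CC1c1ccc(F)cc1` has not yet been measured. It differs from compound 1 in one place only: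

4-fluorophenyl in place of 2,4-dichlorophenyl on a saturated ring carbon

Among the measured compounds shown here, no pair of measured compounds differing in just one place is available, so there is no measured step to lean on. Compound 2 differs from compound 1 in several places at once and gives no guide to this particular change. The expectation is therefore a cautious one: compound 3 is estimated to sit a little higher than compound 1, the step of a 1.5-fold higher number from compound 1 to compound 3 (0.16 log units; within the scatter) being expected to be small, possibly within the scatter. Compound 3 is estimated at 8000 nM in this assay, with a range from 3000 nM to 25000 nM.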

Compound 3, half-maximal cytotoxic concentration: 12200 nM
Compound 3: middle estimate off by 1.5-fold (0.18 log units), on the low side; low and high end bracket the measured number.
By their numbers in this assay, from the lowest: compound 1; then compounds 3 and 2 (each within the scatter of the next).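

In this assay the exchange of 2,4-dichlorophenyl for 4-fluorophenyl on this saturated ring carbon gives a 2.2-fold higher number from compound 1 to compound 3 (0.35 log units; beyond the scatter) and so shows that the group held at this position has a measurable bearing on how much compound the cells tolerate. The earlier compounds shown here could not show this, as they differ from each other in several places at once. The step is modest and runs towards more compound being tolerated, with one fluorine in the entering group where the leaving group has two chlorines, but nothing available explains why the number rises.

Chlorines and fluorine change together in this single step, so it remains open whether the rise follows from losing one chlorine, losing both or gaining the fluorine, and a plain phenyl or a 4-chlorophenyl group on the same carbon would help to tell these apart. Also open, on these data alone, is how a group of a quite different kind at this position, such as a cyclohexyl ring or a short chain ending in an amine, would fare in this measurement.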